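Chlorophenyl isomer swap on a shared core

The source may hold more compounds than are shown below. What is called first, only, known or untested is meant among the compounds shown, and "the series" means these compounds.

Compound 1 `Clc1ccc(-c2cc(-c3ccsc3)nc(-c3ccccc3Cl)c2)o1` and compound 2 `Clc1ccc(-c2cc(-c3cccs3)nc(-c3ccccc3Cl)c2)o1` share one core and differ only in thiophen-2-yl versus thiophen-3-yl on an aromatic carbon. In an assay on isolated protein for inhibition of DNA topoisomerase 1 (Homo sapiens), tested at 100 uM (a lower number here means a weaker effect, a higher number a stronger effect of the compound at the concentration tested), compound 1 gives 0%, and compound 2 gives 41.3%. For the measured compounds named here, the only measured step, a number 41.3 percentage points higher from compound 1 to compound 2 (beyond the scatter), is large and beyond the scatter. Going by the values given here, on the numbers so far compound 2 stands highest of the two, with compound 1 as its sole neighbour, lying beyond the scatter below it.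

Compound 3 `Clc1ccc(-c2cc(-c3ccc(Cl)o3)cc(-c3cccs3)n2)cc1` has the same atoms as compound 2, joined differently: 4-chlorophenyl in place of 2-chlorophenyl on an aromatic carbon. Among the compounds with values here, no measured step touches the 2-chlorophenyl group; the single step in hand concerns the thiophen-2-yl and thiophen-3-yl groups and does not bear on this change. No direction can therefore be read from the series, and the expected step of a number 6.3 percentage points lower from compound 2 to compound 3 (within the scatter) is set near no change beyond the scatter, with a wide margin on either side. In this assay compound 3 is expected to give 35%, within a range from 5% to 65%.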

Compound 3, a percentage reported as inhibition, at one concentration (the size of the read-out at that concentration, not a potency): 38.9%
For compound 3 the middle estimate is 3.9 percentage points below the measured one; low and high end bracket the measured number.
By their numbers in this assay, from the lowest: compound 1; then compounds 3 and 2 (each within the scatter of the next).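

In this assay, 4-chlorophenyl in place of 2-chlorophenyl, on the aromatic carbon next to the ring nitrogen, gives a number 2.4 percentage points lower from compound 2 to compound 3 (within the scatter), so the two chlorophenyl isomers are not separated by this read-out. For the compounds shown here, this is the first information on this position, and it contrasts with the thiophene swap on the same series, a number 41.3 percentage points higher from compound 1 to compound 2 (beyond the scatter): the chlorine can occupy either of these two places on the phenyl ring without a change beyond the scatter, at least alongside thiophen-2-yl. No supporting data on hand account for this result.

Still open is whether the same holds alongside thiophen-3-yl, the partner group of compound 1 at 0%, since the chlorophenyl pair shown carries thiophen-2-yl only. Also open, as far as these compounds go, is what a 3-chlorophenyl group, or a phenyl ring bearing an amine or a carboxylic acid in place of the chlorine, would give at this position, and how the single-concentration numbers would translate into potency.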